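The source may report more compounds than this note shows. Statements on the series, on what has been measured and on what is new or still open speak of the compounds shown alone.

Of the compounds shown here, three have been measured in a functional assay on HEK293 cells for agonist activity at D(4) dopamine receptor (Homo sapiens), read by FLIPR; a higher number here means that more compound is needed for the effect, a lower number that less compound is needed. Compound 1 `O=C(NCN1CCC(c2cccc[n+]2[O-])CC1)c1cnccc1Cl` gives 1290 nM, compound 2 `CCc1cccc(C)c1NC(=O)CN1CCC(c2ccccn2)CC1` gives 111 nM, and compound 3 `COc1cccc(C)c1NC(=O)CN1CCC(c2cccc[n+]2[O-])CC1` gives 340 nM. Compound 3 thus stands second highest of the three numbers: compound 2 sits nearest, at a lower number beyond the scatter, and compound 1 sits furthest, at a higher number beyond the scatter.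

Compound 4 `COc1cccc(C)c1NC(=O)CN1CCC(c2ccccn2)CC1` is not yet measured. It differs from compound 3 in one place: a group of 6 heavy atoms (5 carbon, 1 nitrogen; one six-membered aromatic ring with 1 hetero atom) in place of a group of 7 heavy atoms (5 carbon, 1 nitrogen, 1 oxygen; one six-membered aromatic ring with 1 hetero atom), on a saturated ring carbon. The change sits on a saturated ring carbon of the six-membered non-aromatic ring with one nitrogen, three ring bonds from the ring nitrogen.

Compound 2 carries the same pyridin-2-yl group on that ring carbon and gives the lowest number of the three, while compound 3 and compound 1, both carrying the seven-atom group, give the higher numbers. On that basis compound 4 is expected to need less compound than compound 3, with an expected step of a 3.1-fold lower number from compound 3 to compound 4 (0.49 log units; beyond the scatter) in this assay. The estimate for compound 4 is 110 nM, within a range of 40 nM to 300 nM.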

Compound 4, half-maximal effective concentration: 40 nM
Compound 4: middle estimate off by 2.8-fold (0.44 log units), on the high side, and the stated range covers the measured number.
By their numbers in this assay, from the lowest: compound 4; then compound 2; then compound 3; then compound 1.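

In this assay, among the compounds shown here, pyridin-2-yl in place of the group of 7 heavy atoms on the saturated ring carbon gives an 8.5-fold lower number from compound 3 to compound 4 (0.93 log units; beyond the scatter) with the rest of the structure unchanged, a single-place comparison at this position that the earlier compounds did not offer. With pyridin-2-yl held fixed, methoxy in place of ethyl on an aromatic carbon gives a 2.8-fold lower number from compound 2 to compound 4 (0.44 log units; beyond the scatter), so the number also responds to a change elsewhere in the structure. No evidence is available that bears on the reason for either step.

The compounds shown leave open whether the step at the ring carbon keeps its size when ethyl replaces methoxy. They also leave open how phenyl in place of pyridin-2-yl, or chloro or propyl in place of methoxy, would read in this assay.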